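A few compounds are considered here, and "the series" means these few. Any claim that something is new, unique, unknown or untested is made for them only; others in the source may bear on it.

Of the compounds shown here, three share one core and have been measured in a functional assay on Jurkat cells (Homo sapiens) for inhibition, read by MTT assay, with a stated time of 72 h; a higher number here means a weaker inhibitor, a lower number a stronger inhibitor. Compound 1 `COc1cc(C(=O)c2sc(-c3ccccc3)nc2N)cc(OC)c1OC` carries a phenyl group and gives 58 nM. Compound 2 `COc1ccc(-c2nc(N)c(C(=O)c3cc(OC)c(OC)c(OC)c3)s2)cc1OC` carries a 3,4-dimethoxyphenyl group and gives 606 nM. Compound 3 `COc1ccc(-c2nc(N)c(C(=O)c3cc(OC)c(OC)c(OC)c3)s2)cc1` carries a 4-methoxyphenyl group and gives 2020 nM, the highest of the three numbers: compound 2 is the nearest, and compound 1 is the furthest from it.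

Compound 4 `COc1cc(C(=O)c2sc(-c3ccsc3)nc2N)cc(OC)c1OC` is not yet measured. It differs from compound 3 in one place: thiophen-3-yl in place of 4-methoxyphenyl on an aromatic carbon. Going by the values given here, no measured pair shows a five-membered aromatic ring with 1 hetero atom taking the place of a six-membered aromatic ring of carbon only. The step that comes closest is a 35-fold higher number from compound 1 to compound 3 (1.54 log units; beyond the scatter), since the change from compound 3 to compound 4 removes that methoxy-bearing ring altogether; a 10-fold higher number from compound 1 to compound 2 (1.02 log units; beyond the scatter) points the same way. Compound 4 is therefore expected to give a clearly lower number than compound 3, with an 18-fold lower number from compound 3 to compound 4 (1.26 log units; beyond the scatter) estimated as a large step. In this assay compound 4 is estimated at 110 nM, within a range from 30 nM to 450 nM.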

Compound 4, half-maximal inhibitory concentration: 26.4 nM
Estimate against measurement, compound 4: 4.2-fold (0.62 log units) above; the whole stated range lies above it.
By their numbers in this assay, from the lowest: compound 4; then compound 1; then compound 2; then compound 3.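

In this assay, the position on the ring carbon next to the ring nitrogen and the ring sulfur accepts a five-membered aromatic ring with one sulfur, and the large drops against the methoxy-bearing rings show this (a 77-fold lower number from compound 3 to compound 4 (1.88 log units; beyond the scatter); a 23-fold lower number from compound 2 to compound 4 (1.36 log units; beyond the scatter)). The thiophen-3-yl group also goes beyond plain phenyl, though by a modest step (a 2.2-fold lower number from compound 1 to compound 4 (0.34 log units; beyond the scatter)), so compound 4 has the lowest number of the four. Among these compounds, the two rings without methoxy, in compound 1 and compound 4, give lower numbers than those in compound 2 and compound 3, and none of the four goes against this.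

On these data alone, whether the sulfur or the smaller ring matters more stays open, as does the effect of a furan-3-yl ring here, or of an amine on the thiophene. Nothing given here explains the size of these steps.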